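The compounds below may be only part of what the source reports. "The series", "measured", "known", "first", "only" and "open" are said of these compounds alone.

Measured so far in an ADME assay on cells (Hepatocyte, Homo sapiens) for metabolic stability; a lower number here means that the compound disappears faster, a higher number that the compound lasts longer:
compound 1 `CCc1nc2ccc(Cl)cn2c1C(=O)NCCOc1ccc(Cl)cc1`: 0.215 h
compound 2 `CCc1nc2ccc(C)cn2c1C(=O)NCCOc1ccc(OC)cc1`: 0.325 h

These two compounds differ in more than one place, so their numbers cannot be tied to any single structural change. Compound 2 gives 0.325 h, which lies within the scatter of the number given by compound 1, 0.215 h. Within the data shown here, compound 2 therefore stands level with the only other number available, and neither compound can be placed ahead of the other.

The next compound to be measured is compound 3 `COc1ccc(OCCNC(=O)c2c(C3CC3)nc3ccc(C)cn23)cc1`. It keeps compound 2 unchanged except at one place, with cyclopropyl in place of ethyl on an aromatic carbon. Among the measured compounds shown here, no measured pair shows this exchange, so the expectation in this assay has no direct precedent and remains uncertain. The expected change is small and upward, and it would probably stay within the scatter. In numbers, the estimated change is a 1.2-fold higher number from compound 2 to compound 3 (0.09 log units; within the scatter). For compound 3 the expected half-life is 0.4 h, with an estimated range from 0.2 h to 0.8 h.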

Compound 3, half-life: 0.13 h
For compound 3 the middle estimate is 3.1-fold (0.49 log units) above the measured one; measured number outside the range, below it.
By their numbers in this assay, from the lowest: compounds 3, 1 and 2 (each within the scatter of the next, the first and the last beyond it).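

In this assay, among these compounds, putting cyclopropyl in place of ethyl on an aromatic carbon of the five-membered aromatic ring gives a 2.5-fold lower number from compound 2 to compound 3 (0.40 log units; beyond the scatter) and so provides the first step in this set that can be tied to a single structural change. The result shows that this position, next to the ring nitrogen, is not indifferent to the group it carries: with the rest of compound 2 unchanged, this one exchange shortens the half-life by more than the scatter of the measurement. No available evidence accounts for this step.

The compounds shown leave open whether the shorter half-life belongs to the three-membered ring itself or would also follow from other groups at this position, such as a methyl, an isopropyl or a longer chain like propyl. They also leave open whether the same exchange would give a step of similar size in compound 1, which carries chlorine on both the shared core and the far aromatic ring.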